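Moving a Methyl Group on a Pyridinyl Sulfonyl Substituent

The source may report more compounds than this note shows. Statements on the series, on what has been measured and on what is new or still open speak of the compounds shown alone.

In an ADME assay on the whole organism (plasma, Rattus norvegicus, strain Sprague-Dawley) for pharmacokinetics, read by LC-MS, using cassette dosing, at a dose of 0.2 mg/kg by the intravenous route (on this read-out higher numbers stand for higher exposure at the dose given and lower numbers for lower exposure), compound 1 (`CNCc1cn(S(=O)(=O)c2ccccn2)c(-c2cccnc2F)c1F`) gives 33 ng.h/mL and compound 2 (`CNCc1cn(S(=O)(=O)c2cccnc2C)c(-c2cccnc2F)c1F`) gives 32 ng.h/mL as its value. For the measured compounds named here, compound 2 therefore stands level with compound 1 on the only two numbers available, since the measured step is a 1.0-fold lower number from compound 1 to compound 2 (0.01 log units; within the scatter) for this swap: 2-methylpyridin-3-yl in place of pyridin-2-yl on a sulfonyl sulfur.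

Compound 3 (`CNCc1cn(S(=O)(=O)c2cnccc2C)c(-c2cccnc2F)c1F`) has not yet been measured. Its difference from compound 2 is 4-methylpyridin-3-yl in place of 2-methylpyridin-3-yl on a sulfonyl sulfur and in plain words 4-methylpyridin-3-yl takes the place of 2-methylpyridin-3-yl on a sulfonyl sulfur. The atoms stay the same and are only joined differently.

Going by the values given here, one measured step bears on this change, and it concerns a different pair of groups on the same sulfonyl sulfur. Compound 2 came out of that swap with a step of a 1.0-fold lower number from compound 1 to compound 2 (0.01 log units; within the scatter) as its size, so no change beyond the scatter is expected in this assay and neither direction is favoured. The expected step is no change at the digits printed from compound 2 to compound 3 (within the scatter) in this estimate. Compound 3 is estimated at 32 ng.h/mL with a likely range from 14 ng.h/mL to 72 ng.h/mL as its span.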

Compound 3, area under the concentration-time curve: 41 ng.h/mL
Estimate against measurement, compound 3: 1.3-fold (0.11 log units) below, and the stated range covers the measured number.
By their numbers in this assay, from the lowest: compounds 2, 1 and 3 (each within the scatter of the next).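

Moving the methyl group, so that 4-methylpyridin-3-yl stands on the sulfonyl sulfur where 2-methylpyridin-3-yl stood, gives a 1.3-fold higher number from compound 2 to compound 3 (0.11 log units; within the scatter) in this assay, and the atoms of the two groups are the same, only joined differently. Set against the pyridin-2-yl group, which has no methyl at all, the same group gives a 1.2-fold higher number from compound 1 to compound 3 (0.09 log units; within the scatter), so the earlier finding now extends to a second methylpyridinyl group, and the three compounds cannot be told apart on this read-out. Nothing measured here offers an explanation for how closely these numbers agree.

From the compounds shown here alone, the three groups are all pyridine rings, with a methyl group or none, so it remains open whether a larger change on the sulfonyl sulfur, such as a plain phenyl ring or a pyridine ring carrying an amine or a carboxylic acid, would move exposure beyond the scatter. A single exposure number per compound also leaves open how these compounds compare on any other pharmacokinetic read-out.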